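A few compounds are considered here, and "the series" means these few. Any claim that something is new, unique, unknown or untested is made for them only; others in the source may bear on it.

Working notes on the series, all values from a functional assay on HeLa cells (Homo sapiens) for cytotoxicity, read by sulforhodamine B assay, with a stated time of 48 h; a lower number here means a stronger inhibitor of growth, a higher number a weaker inhibitor of growth:

- compound 1 `Cc1nn(-c2ccccc2)c(Oc2ccc(-c3nc4cc([N+](=O)[O-])ccc4[nH]3)cc2)c1/C=N/Nc1ccccc1`: 20200 nM
- compound 2 `Cc1nn(-c2ccccc2)c(Oc2ccc(-c3nc4cc([N+](=O)[O-])ccc4[nH]3)cc2)c1/C=N/NC(N)=S`: 6600 nM
- compound 3 `Cc1nn(-c2ccccc2)c(Oc2ccc(-c3nc4cc(C(=O)O)ccc4[nH]3)cc2)c1/C=N/Nc1ccccc1`: 15000 nM

Compound 3 stands with compound 1 at the high end of these numbers, and the two are not separated: a 1.3-fold lower number from compound 1 to compound 3 (0.13 log units; within the scatter). Compound 2 alone has a clearly lower number.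

The next compound to be measured is compound 4 `Cc1nn(-c2ccccc2)c(Oc2ccc(-c3nc4cc(C(=O)O)ccc4[nH]3)cc2)c1/C=N/NC(N)=S`. Its structural change is a group of 3 heavy atoms (1 carbon, 1 nitrogen, 1 sulfur; no ring) in place of a group of 6 heavy atoms (6 carbon; one six-membered aromatic ring of carbon only), on an amine nitrogen, placed on an amine nitrogen whose other neighbours are: double-bonded nitrogen.

The same exchange has been measured once, with nitro in place of carboxy on the aromatic carbon: a 3.1-fold lower number from compound 1 to compound 2 (0.49 log units; beyond the scatter). That modest step is the direct precedent. The other measured step bears on it indirectly: a 1.3-fold lower number from compound 1 to compound 3 (0.13 log units; within the scatter), so the two starting compounds sit close together. Among the compounds with values here, whether the exchange carries over to the carboxy compounds is untested, as only one pair supports it.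

A step of similar size toward a lower number is therefore expected in this assay, estimated as a 3.0-fold lower number from compound 3 to compound 4 (0.48 log units; beyond the scatter). For compound 4 the estimated value is 5000 nM, with an expected range from 2200 nM to 12000 nM.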

Compound 4, concentration for 50% growth inhibition: 22700 nM
Estimate against measurement, compound 4: 4.5-fold (0.66 log units) below; the measured number lies above the stated range.
By their numbers in this assay, from the lowest: compound 2; then compounds 3, 1 and 4 (each within the scatter of the next).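

In this assay, with carboxy on the aromatic carbon, the group that enters in place of phenyl on the amine nitrogen brings no lowering of the number: the step is a 1.5-fold higher number from compound 3 to compound 4 (0.18 log units; within the scatter). The exchange therefore does not carry over from the nitro compounds, and its outcome on this amine nitrogen depends on whether the core carries nitro or carboxy: the same change on two cores in this assay, a 3.1-fold lower number (0.49 log units; beyond the scatter) from compound 1 to compound 2 and a 1.5-fold higher number (0.18 log units; within the scatter) from compound 3 to compound 4, 4.6-fold (0.67 log units) apart, beyond the scatter of two such steps Read from the other side, the two compounds with phenyl on the amine nitrogen are not separated, whereas with the entering group there, carboxy in place of nitro gives a 3.4-fold higher number from compound 2 to compound 4 (0.54 log units; beyond the scatter), so this pair alone shows a clear difference between nitro and carboxy: the same change on two cores in this assay, a 1.3-fold lower number (0.13 log units; within the scatter) from compound 1 to compound 3 and a 3.4-fold higher number (0.54 log units; beyond the scatter) from compound 2 to compound 4, 4.6-fold (0.67 log units) apart, beyond the scatter of two such steps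

The four compounds form a single set of paired changes in one cell assay, so they show that the two changes interact but not why, and they give no measured property of either group that could account for it. From the compounds shown here alone, whether the dependence extends beyond nitro and carboxy remains open, for example with an amine on the aromatic carbon or a short alkyl chain on the amine nitrogen.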